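The compounds below may be only part of what the source reports. "The series", "measured", "known", "first", "only" and "open" are said of these compounds alone.

Working notes on the series. All three measured compounds share one core and differ only in the aryl ester part. Compound 1 `COC(=O)c1ccc(C)cc1OC(=O)COc1cc(O)c2c(=O)cc(-c3ccccc3)oc2c1` carries a methyl on that ring; in an ADME assay on cells (T-cell, Mus musculus, strain BALB/c) for cytotoxicity, read by MTT assay, with a stated time of 48 h (on this read-out higher numbers stand for lower toxicity in this test and lower numbers for higher toxicity in this test), compound 1 gives 250000 nM. Compound 2 `COC(=O)c1ccc(Cl)cc1OC(=O)COc1cc(O)c2c(=O)cc(-c3ccccc3)oc2c1` carries a chloro instead, and compound 2 gives 265000 nM; the change is a 1.1-fold higher number from compound 1 to compound 2 (0.03 log units; within the scatter). Compound 3 `COC(=O)c1cc(Br)ccc1OC(=O)COc1cc(O)c2c(=O)cc(-c3ccccc3)oc2c1` carries a bromo on a ring with the methoxycarbonyl group in a different arrangement. For compound 3 the read-out is a limit of the assay and not a number: compound 3 gives > 450000 nM, as noted in the limit of > 450000 nM in this assay, at which 1 of the 3 values shown sits. Against the two numbers, compound 3 therefore stands at the top of what is shown, with an at least 1.8-fold higher number from compound 1 to compound 3 (0.25 log units; that floor lies within the scatter) and an at least 1.6-fold higher number from compound 2 to compound 3 (0.22 log units; that floor lies within the scatter), both floors lying within the scatter.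

Compound 4 `COC(=O)c1cc(F)ccc1OC(=O)COc1cc(O)c2c(=O)cc(-c3ccccc3)oc2c1` differs from compound 3 in one place: fluoro in place of bromo on an aromatic carbon. Within the data shown here, the steps that bear on this are the halogen-for-methyl exchange, which stayed within the scatter, and the two steps into compound 3, which give only floors within the scatter. No measured halogen-for-halogen exchange exists in the set. Expectation: no step beyond the scatter, and a good chance that the read-out is again a limit. Compound 4 is estimated at 400000 nM, range 200000 nM to 900000 nM. The expected step is an at least 1.1-fold lower number from compound 3 to compound 4 (0.05 log units; that floor lies within the scatter).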

Compound 4, half-maximal cytotoxic concentration: 389000 nM
Beside the measured number, compound 4's estimate is 1.0-fold (0.01 log units) above it; the measured number falls inside the stated range.
By their numbers in this assay, from the lowest: compounds 1, 2 and 4 (each within the scatter of the next). At a limit, above all of these: compound 3.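

Compound 4 puts a halogen-for-halogen exchange on record at this place, meta to a methoxycarbonyl group and para to a large group, and the fluoro compound returns a number and not a limit, with an at least 1.1-fold lower number from compound 3 to compound 4 (0.06 log units; that floor lies within the scatter). The read-out of compound 3 is a limit of the assay, so the true size of this exchange stays unknown: the limit of > 450000 nM in this assay, at which 1 of the 4 values shown sits.

Compound 4 can also be set against the two other aryl esters, with a 1.5-fold higher number from compound 2 to compound 4 (0.17 log units; within the scatter) and a 1.6-fold higher number from compound 1 to compound 4 (0.19 log units; within the scatter); both steps lie within the scatter, so in this assay the fluoro compound does not separate from the chloro or methyl compounds, even though its ring arrangement matches that of compound 3.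

As far as these compounds go, whether an amine or a nitrile at this same place, or a carboxylic acid in place of the methoxycarbonyl group, would move the read-out beyond the scatter stays open. Also open, from the compounds shown here alone, is whether any change to the shared core, as opposed to the aryl ester part, would bring a step beyond the scatter in this test.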